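The source may report more compounds than this note shows. Statements on the series, on what has been measured and on what is new or still open speak of the compounds shown alone.

Measured in a functional assay on CCRF-CEM cells (Homo sapiens) for antiproliferative activity; on this read-out higher numbers stand for weaker inhibition of growth and lower numbers for stronger inhibition of growth:
- compound 1 `CCCCCOCCCCCCC/C=C1\CC(CO)(COC(=O)C(C)(C)C)OC1=O`: 0.877 ug/mL
- compound 2 `CC(C)(C)C(=O)OCC1(CO)C/C(=C\CCCCCCCCCCCCCCC=O)C(=O)O1`: 0.933 ug/mL

Within the data shown here, compound 2 stands within the scatter of the only other measured compound, so neither can be ranked above the other. Compound 3 `CC(=O)OCCCCCCCCCCCCCCC/C=C1\CC(CO)(COC(=O)C(C)(C)C)OC1=O` differs from compound 2 by acetoxymethyl in place of formyl on a saturated chain carbon, ten or more bonds along the chain from a double-bonded chain carbon. Among the measured compounds shown here, one measured step bears on this, also a change on a saturated chain carbon: a 1.1-fold higher number from compound 1 to compound 2 (0.03 log units; within the scatter). For the measured compounds named here, with only that step to go on, no shift beyond the scatter is expected in this assay. The expected step is a 1.0-fold lower number from compound 2 to compound 3 (0.02 log units; within the scatter). For compound 3 the estimated value is 0.9 ug/mL, with an expected range of 0.4 ug/mL to 2 ug/mL.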

Compound 3, concentration for 50% growth inhibition: 7.55 ug/mL
Beside the measured number, compound 3's estimate is 8.4-fold (0.92 log units) below it; the whole stated range lies below it.
By their numbers in this assay, from the lowest: compounds 1 and 2 (each within the scatter of the next); then compound 3.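

In this assay this place on the chain is no longer silent: acetoxymethyl in place of formyl gives an 8.1-fold higher number from compound 2 to compound 3 (0.91 log units; beyond the scatter), and 8-acetoxyoctyl in place of pentyloxy gives an 8.6-fold higher number from compound 1 to compound 3 (0.93 log units; beyond the scatter). The swap of pentyloxy for 7-formylheptyl had stayed within the scatter, so a change here can weaken growth inhibition clearly. Nothing given here accounts for the shift. The compounds shown leave open whether a carboxylic acid or an amine on this saturated chain carbon would read like compound 2 or like compound 3.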